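The source may report more compounds than this note shows. Statements on the series, on what has been measured and on what is new or still open speak of the compounds shown alone.

Working notes on the series.

Compound 1 `CCc1ccccc1N(CC(=O)NCc1cccc(Cl)c1)S(=O)(=O)c1ccc(C)cc1` gives 1410 nM in a functional assay on CHO-K1 cells for antagonist activity at prostaglandin E2 receptor EP1 subtype (Homo sapiens), read by FLIPR and calcium flux; on this read-out lower numbers stand for stronger inhibition and higher numbers for weaker inhibition. Within the data shown here, compound 2 `CCc1ccccc1N(CC(=O)NCc1ccc(Br)cc1)S(=O)(=O)c1ccc(C)cc1` gives 22.9 nM; it stands at the lowest number of the two measured, with compound 1 as its only neighbour, and the step of a 62-fold lower number from compound 1 to compound 2 (1.79 log units; beyond the scatter) separates them. Compound 3 `CCc1ccccc1N(CC(=O)NCc1ccccc1F)S(=O)(=O)c1ccc(C)cc1` is not yet measured; it differs from compound 2 by 2-fluorophenyl in place of 4-bromophenyl on a saturated chain carbon bound to an amide-type nitrogen. Among the measured compounds shown here, the single measured step bears on it only loosely, since a change of halogen and of its position on the benzyl ring moved the number strongly there. A step of a 13-fold higher number from compound 2 to compound 3 (1.12 log units; beyond the scatter) towards a higher number is therefore expected for compound 3, with an estimate of 300 nM and a range of 50 nM to 3000 nM.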

Compound 3, inhibition constant: 135 nM
For compound 3 the middle estimate is 2.2-fold (0.35 log units) above the measured one, and the stated range covers the measured number.
By their numbers in this assay, from the lowest: compound 2; then compound 3; then compound 1.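

In this assay the 2-fluorophenyl group places compound 3 inside the range of the two earlier compounds, with a 5.9-fold higher number from compound 2 to compound 3 (0.77 log units; beyond the scatter) and a 10-fold lower number from compound 1 to compound 3 (1.02 log units; beyond the scatter) on either side. A third halogen and ring placement thus gives a third distinct level at this position, and 4-bromophenyl remains the lowest of the three. No measurement here accounts for these differences.

Halogen and its place on the ring change together in all three compounds, so their separate contributions cannot be read. On these data alone, how an unsubstituted phenyl ring, or a methoxy group or an amine on that ring, would compare also stays open.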